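The source may report more compounds than this note shows. Statements on the series, on what has been measured and on what is new or still open speak of the compounds shown alone.

Measured so far in a functional assay on the whole organism (strain Swiss) with Mus musculus as the target, in the maximal electroshock model, with a stated time of 1 h, at a dose of 300 mg/kg by the intraperitoneal route; on this read-out lower numbers stand for a weaker effect and higher numbers for a stronger effect at the one dose given:
Compound 1 `CC(C(=O)N1CCN(c2ccccc2)CC1)N1C(=O)CCC1=O`: 50%
Compound 2 `CCC(C(=O)N1CCN(c2cccc(C(F)(F)F)c2)CC1)N1C(=O)CCC1=O`: 100%

Compound 1 stands lowest of the two numbers. Its nearest neighbour, compound 2, differs from it in more than one place, so the two values can only be set side by side: compound 2 reaches 100%, a gap beyond the usual scatter of this assay, while compound 1 sits at 50%.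

Compound 3 `CC(C(=O)N1CCN(c2cccc(Cl)c2)CC1)N1C(=O)CCC1=O` has not yet been tested. It differs from compound 1 in a single place: chloro in place of hydrogen on an aromatic carbon. Going by the values given here, no pair of measured compounds shows this exact change on its own, so no step can be read off directly. Still, compound 2, whose ring bears a trifluoromethyl group, gives 100%, and this supports an expected rise rather than a fall. The step of a number 30 percentage points higher from compound 1 to compound 3 (beyond the scatter) is expected to be upward and beyond the scatter. Compound 3 is therefore estimated at 80%, with a likely range from 50% to 100%.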

Compound 3, a percentage reported as activity, at one dose (the size of the read-out at that dose, not a potency): 75%
Beside the measured number, compound 3's estimate is 5 percentage points above it; measured number inside the range.
By their numbers in this assay, from the lowest: compound 1; then compound 3; then compound 2.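

A step of a number 25 percentage points higher from compound 1 to compound 3 (beyond the scatter) in this assay comes from chloro in place of hydrogen alone, with the rest of the molecule unchanged. Going by these compounds alone, this is the first change that can be read on its own: a substituent on this aromatic carbon, meta to a large group, can raise the read-out, and a single chlorine atom is enough to do so here. Nothing at hand explains why this single atom has this effect.

The compounds shown leave open how other groups at this same place, such as fluoro, methoxy or an amine, would compare, and whether chloro would act alike on another carbon of the ring. Compound 2 carries more than one difference from compound 1, so the share of its trifluoromethyl group cannot be read separately.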